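Exchanging the Pyrimidine Partner in Compound 2

A few compounds are considered here, and "the series" means these few. Any claim that something is new, unique, unknown or untested is made for them only; others in the source may bear on it.

Of the compounds shown here, two with a shared core have been measured. Compound 1 `COc1cc2nc(N3CCN(c4ncccn4)CC3)nc(N)c2cc1OC` carries an unsubstituted pyrimidinyl group on an amine nitrogen in a ring, and in an assay on brain for binding affinity to Adrenergic receptor alpha-1 (Rattus norvegicus) (on this read-out lower numbers stand for stronger inhibition and higher numbers for weaker inhibition), compound 1 gives 0.26 nM. Compound 2 `COc1cc2nc(N3CCN(c4nccc(C)n4)CC3)nc(N)c2cc1OC` differs only by a methyl group on an aromatic carbon, and in this assay compound 2 gives 0.92 nM. That single change produced a 3.5-fold higher number from compound 1 to compound 2 (0.55 log units; beyond the scatter). Among the two numbers compound 2 stands highest, meaning it binds more weakly, and its only neighbour is compound 1.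

Compound 3 `CCCOc1cc(N2CCN(c3nc(N)c4cc(OC)c(OC)cc4n3)CC2)ncn1` has not yet been measured. It differs from compound 2 by 6-propoxypyrimidin-4-yl in place of 4-methylpyrimidin-2-yl on an amine nitrogen in a ring. Going by the values given here, the only measured step that bears on it is a 3.5-fold higher number from compound 1 to compound 2 (0.55 log units; beyond the scatter), which touched a small substituent on the same ring, whereas here the whole ring is exchanged and enlarged, a change without direct precedent in these data. Compound 3 is therefore expected to sit near compound 2 or somewhat weaker, an expected step of a 1.7-fold higher number from compound 2 to compound 3 (0.24 log units; within the scatter). The estimate for compound 3 is 1.6 nM, with a range from 0.3 nM to 8 nM.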

Compound 3, inhibition constant: 0.36 nM
The estimate for compound 3 lay 4.4-fold (0.65 log units) above the measured number; the measured number falls inside the stated range.
By their numbers in this assay, from the lowest: compounds 1 and 3 (each within the scatter of the next); then compound 2.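

In this assay, this position on the amine nitrogen in a ring turns out to tolerate a much bigger change than the methyl group alone suggested: replacing 4-methylpyrimidin-2-yl with 6-propoxypyrimidin-4-yl, a group with more heavy atoms, gave a 2.6-fold lower number from compound 2 to compound 3 (0.41 log units; beyond the scatter) and so did not weaken binding. Set against the unsubstituted pyrimidin-2-yl, the same group gave a 1.4-fold higher number from compound 1 to compound 3 (0.14 log units; within the scatter) and therefore leaves compound 3 level with compound 1 within the scatter, so among these three compounds a larger group does not go with a higher number, with the small methyl of compound 2 giving the highest value. No measurement at hand explains why the methyl-bearing ring fares worse than the larger propoxy-bearing one.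

Going by these compounds, compound 3 differs from compound 1 in two features at once, the propoxy group and the way the pyrimidine is attached, and the share of each in the result stays open. Also open, on these data alone, is whether a longer chain such as butoxy, or a carboxylic acid in place of the propoxy group, would keep the number as low.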